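The source may hold more compounds than are shown below. What is called first, only, known or untested is meant among the compounds shown, and "the series" means these compounds.

Measured so far in a physicochemical assay for permeability, using PAMPA, at pH 7.4; a higher number here means that the compound crosses the layer faster, a lower number that the compound crosses the layer more slowly:
- compound 1 `CC(C)NCCS(=O)(=O)NC(=O)c1ccc(Nc2nc(NC3(c4ccc(Cl)cc4)CC3)nc(OCC(F)(F)F)n2)cc1` gives 45 nm/s
- compound 2 `CC(=O)NCCS(=O)(=O)NC(=O)c1ccc(Nc2nc(NC3(c4ccc(Cl)cc4)CC3)nc(OCC(F)(F)F)n2)cc1` gives 7 nm/s

Compound 2 has the lowest of the two numbers; the change from compound 1 gave a 6.4-fold lower number from compound 1 to compound 2 (0.81 log units; beyond the scatter). Compound 3 `COC(=O)NCCS(=O)(=O)NC(=O)c1ccc(Nc2nc(NC3(c4ccc(Cl)cc4)CC3)nc(OCC(F)(F)F)n2)cc1` differs from compound 2 by methoxy in place of methyl on a carbonyl carbon. Among the measured compounds shown here, no measured pair shows this same change; the step from compound 1 to compound 2 is the only step known, and it concerns a different exchange. The expected step from compound 2 to compound 3 is therefore small, a 1.3-fold higher number from compound 2 to compound 3 (0.11 log units; within the scatter), and not clearly beyond the scatter in either direction. Compound 3 is estimated at 9 nm/s, within a range of 4 nm/s to 20 nm/s.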

Compound 3, apparent permeability: 39 nm/s
Beside the measured number, compound 3's estimate is 4.3-fold (0.64 log units) below it; the whole stated range lies below it.
By their numbers in this assay, from the lowest: compound 2; then compounds 3 and 1 (each within the scatter of the next).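

On the carbonyl carbon of this side chain, methoxy in place of methyl gives a 5.6-fold higher number from compound 2 to compound 3 (0.75 log units; beyond the scatter) in this assay and so shows that a small exchange at this place can matter. Methoxycarbonyl in place of isopropyl on the amine nitrogen gives a 1.2-fold lower number from compound 1 to compound 3 (0.06 log units; within the scatter) and so shows that not every carbonyl group on this nitrogen goes with a low number, as the acetyl of compound 2 does. On these data alone, whether an amine or a longer chain such as ethoxy on this carbonyl carbon would follow methoxy or methyl remains open. No measurement here gives a reason for the difference between methoxy and methyl.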